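This account rests on a few compounds, and the source may have more. Where it says the series, first, only, none or still open, it means among the compounds named here.

In a functional assay on A549 cells (Homo sapiens) for inhibition, read by sulforhodamine B assay, with a stated time of 48 h, tested at 10 uM (a higher number here means more inhibition at the concentration tested (going by the name of the read-out), a lower number less inhibition), compound 1 `c1ccc(-c2cn3ccnc3c(-c3ccc4ncn(C5CCCCC5)c4c3)n2)cc1` gives 33.3%, compound 2 `Fc1ccc(-c2cn3ccnc3c(-c3ccc4ncn(C5CCCCC5)c4c3)n2)cc1` gives 12.8%, and compound 3 `COc1ccccc1-c1cn2ccnc2c(-c2ccc3ncn(C4CCCCC4)c3c2)n1` gives 13.9%. Compound 3 thus stands second highest of the three: its value lies within the scatter of that of compound 2, while the step of a number 19.4 percentage points lower from compound 1 to compound 3 (beyond the scatter) lies beyond it. For the measured compounds named here, compound 4 `c1csc(-c2cn3ccnc3c(-c3ccc4ncn(C5CCCCC5)c4c3)n2)c1` differs from compound 3 in one place: thiophen-2-yl in place of 2-methoxyphenyl on an aromatic carbon No measured step involves thiophen-2-yl. Going by the values given here, two steps bear indirectly: a number 19.4 percentage points lower from compound 1 to compound 3 (beyond the scatter), where methoxy in place of hydrogen went with a lower number, and a number 1.1 percentage points higher from compound 2 to compound 3 (within the scatter), where changing one ring group for another changed nothing beyond the scatter. Because compound 1, carrying hydrogen rather than methoxy, gave 33.3%, a modest rise is expected. The expected step is a number 8.1 percentage points higher from compound 3 to compound 4 (within the scatter). Compound 4 is estimated at 22%, within 5% to 40%.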

Compound 4, a percentage reported as inhibition, at one concentration (the size of the read-out at that concentration, not a potency): 5.33%
Compound 4: the middle estimate sits 16.7 percentage points above what was measured; measured number inside the range.
By their numbers in this assay, from the lowest: compounds 4, 2 and 3 (each within the scatter of the next); then compound 1.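

In this assay the five-membered thiophen-2-yl ring at this position gives a number 28 percentage points lower from compound 1 to compound 4 (beyond the scatter) when it replaces plain phenyl. Against the substituted phenyl rings it gives a number 7.5 percentage points lower from compound 2 to compound 4 (within the scatter) and a number 8.6 percentage points lower from compound 3 to compound 4 (within the scatter) so compounds 2, 3 and 4 form one group, and of the four compounds only compound 1, with plain phenyl, stands apart. Nothing available gives a reason for this. Still open, going by these compounds, is how a carboxylic acid or an amine on the phenyl ring would read here. On these data alone, whether any group at this position can rise above compound 1 also remains open.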